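A few compounds are considered here, and "the series" means these few. Any claim that something is new, unique, unknown or untested is made for them only; others in the source may bear on it.

Compound 3 `CC(=O)N(Cc1cccc(F)c1F)Cc1cn(S(=O)(=O)c2ccc(F)cc2)c2ccccc12` gives 25.8% in a functional assay on 3T3-L1 cells (Mus musculus) for inhibition, with a stated time of 20 min, tested at 20 uM; on this read-out lower numbers stand for less inhibition and higher numbers for more inhibition at the one concentration tested (going by the name of the read-out). Among the three compounds measured so far it stands second highest: its nearest neighbour is compound 2 `Cc1ccc(S(=O)(=O)n2cc(CNCc3cccc(F)c3F)c3ccccc32)cc1`, which gives 46% and lies above it beyond the scatter, while compound 1 `Cc1ccc(S(=O)(=O)n2cc(CN(Cc3cccc(F)c3F)C(=O)C(F)(F)F)c3ccccc32)cc1` gives -5.5% and lies furthest from it, well below and again beyond the scatter. Within the data shown here, the one measured step within this set, a number 51.5 percentage points higher from compound 1 to compound 2 (beyond the scatter), concerns a different part of the molecule from the change considered here.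

Compound 4 `CC(=O)N(Cc1cccc(F)c1F)Cc1cn(S(=O)(=O)c2ccc(C)cc2)c2ccccc12` is obtained from compound 3 by a single change, (methyl in place of fluoro on an aromatic carbon), with methyl in place of fluoro on an aromatic carbon, para to a large group; read one bond further out, the (4-fluorophenyl)sulfonyl group becomes a (4-methylphenyl)sulfonyl group. Among the measured compounds shown here, no measured step isolates this exchange: compounds 1 and 2 carry the methyl group, but each differs from compound 3 in a second place as well, so their values cannot be read as a step for the methyl alone. In the absence of a bearing step, the expected change a number 0.2 percentage points higher from compound 3 to compound 4 (within the scatter) is none beyond the scatter. Compound 4 is therefore estimated at 26%, with a range from 10% to 42%.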

Compound 4, a percentage reported as inhibition, at one concentration (the size of the read-out at that concentration, not a potency): 57.5%
Compound 4: the middle estimate sits 31.5 percentage points below what was measured; the whole stated range lies below it.
By their numbers in this assay, from the lowest: compound 1; then compound 3; then compound 2; then compound 4.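

Among these compounds, the exchange on the sulfonyl aryl ring, read on its own for the first time, is far from neutral: in this assay there is a number 31.7 percentage points higher from compound 3 to compound 4 (beyond the scatter) even though one heavy atom replaces another and the counted donors, acceptors and net charge stay the same. With the (4-methylphenyl)sulfonyl group held fixed, the substituent on the amine nitrogen also matters, since the acetyl amide shows a number 11.5 percentage points higher from compound 2 to compound 4 (beyond the scatter) against the free amine and a number 63 percentage points higher from compound 1 to compound 4 (beyond the scatter) against the trifluoromethyl amide, which places compound 4 highest of the four compounds beyond the scatter. Nothing available explains why either exchange moves the inhibition in this way.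

Open, going by these compounds, is whether the gain is particular to methyl or would also appear with hydrogen, chlorine, a methoxy group or a longer chain such as ethyl at this place para to a large group. Also open, on these data alone, is whether the difference between fluoro and methyl carries over to the free amine or to the trifluoromethyl amide, and whether the order seen at one concentration would hold across a range of concentrations.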